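The source may report more compounds than this note shows. Statements on the series, on what has been measured and on what is new or still open speak of the compounds shown alone.

Measured in an ADME assay (liver) for metabolic stability, with Liver microsome (Homo sapiens) as the target, using microsomes; on this read-out higher numbers stand for fast clearance and lower numbers for slow clearance:
Compound 1 `COc1ccc(-n2cc3nc(-c4cccnc4C)n(C[C@H]4CCCN(C[C@H]5CCCO5)C4)c(=O)c3n2)cc1`: 21 mL.min-1.g-1
Compound 2 `Cc1ncccc1-c1nc2cn(-c3cccc(OC(C)C)c3)nc2c(=O)n1C[C@H]1CCCN(C[C@H]2CCCO2)C1`: 51 mL.min-1.g-1
Compound 3 `Cc1ncccc1-c1nc2cn(-c3cccc(OC(F)F)c3)nc2c(=O)n1C[C@H]1CCCN(C[C@H]2CCCO2)C1`: 33 mL.min-1.g-1

For the measured compounds named here, only one pair in this set is clearly separated: a 2.4-fold higher number from compound 1 to compound 2 (0.39 log units; beyond the scatter). Compound 3, at 33 mL.min-1.g-1, cannot be told apart from either of the others, since a 1.6-fold higher number from compound 1 to compound 3 (0.20 log units; within the scatter) and a 1.5-fold lower number from compound 2 to compound 3 (0.19 log units; within the scatter) both lie within the scatter.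

The next compound is compound 4 `Cc1ncccc1-c1nc2cn(-c3ccccc3)nc2c(=O)n1C[C@H]1CCCN(C[C@H]2CCCO2)C1`. It keeps the shared core of compound 3 but has hydrogen in place of difluoromethoxy on an aromatic carbon, so that 3-(difluoromethoxy)phenyl becomes phenyl: hydrogen in place of difluoromethoxy on an aromatic carbon.

Going by the values given here, no measured compound has a bare phenyl here, so the data do not test this change directly. The closest evidence is the three steps above, which all alter the substituent on this same phenyl. The largest of them, a 2.4-fold higher number from compound 1 to compound 2 (0.39 log units; beyond the scatter), is only modest, and the other two stay within the scatter. A small step in this assay is therefore expected, perhaps slightly downward, though its direction is uncertain.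

For compound 4 the expected value is 26 mL.min-1.g-1, with an estimated range from 14 mL.min-1.g-1 to 48 mL.min-1.g-1. This estimate corresponds to an expected change of a 1.3-fold lower number from compound 3 to compound 4 (0.10 log units; within the scatter), which would not go beyond the scatter.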

Compound 4, intrinsic clearance in microsomes: 15 mL.min-1.g-1
Beside the measured number, compound 4's estimate is 1.7-fold (0.24 log units) above it; low and high end bracket the measured number.
By their numbers in this assay, from the lowest: compounds 4, 1, 3 and 2 (each within the scatter of the next, the first and the last beyond it).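

In this assay, for the compounds shown here, the bare phenyl gives this position its first reference point, since the earlier steps only exchanged one substituent for another. Against it, removing the difluoromethoxy group gives a 2.2-fold lower number from compound 3 to compound 4 (0.34 log units; beyond the scatter) and removing the isopropoxy group gives a 3.4-fold lower number from compound 2 to compound 4 (0.53 log units; beyond the scatter) so in these two cases a group on the phenyl goes with a higher number than hydrogen does. This does not hold for every substituent: compound 1 goes against it, with a 1.4-fold lower number from compound 1 to compound 4 (0.15 log units; within the scatter) so its 4-methoxyphenyl and the plain phenyl cannot be told apart. Nothing measured here gives a reason for these differences.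

Compound 1 differs from compound 2 and compound 3 both in its group and in where that group sits on the ring, so the two effects remain tangled, and a 3-methoxyphenyl would help to separate them. From the compounds shown here alone, it also remains open whether a fluorine atom, a nitrile or an amine on this phenyl would give a number close to that of compound 4 or one closer to that of compound 2.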